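A Methylsulfonyl Addition to a Compound Without Readable Cytotoxicity

The compounds below may be only part of what the source reports. "The series", "measured", "known", "first", "only" and "open" are said of these compounds alone.

Measured in an ADME assay on NIH3T3 cells (Mus musculus) for cytotoxicity, read by CCK-8 assay, with a stated time of 24 h; on this read-out lower numbers stand for stronger inhibition and higher numbers for weaker inhibition:
Compound 1 `C/C(=C\c1cc(-c2ccccc2)cs1)C(N)=O` gives > 50000 nM, a limit of the assay.
Compound 2 `C/C(=C\c1nc(-c2ccc(F)cc2)cs1)C(N)=O` gives > 50000 nM, a limit of the assay.
Compound 3 `C/C(=C\c1cc(-c2ccccc2C)cs1)C(N)=O` gives > 50000 nM, a limit of the assay.

Compound 1 stands only at a limit in this assay, and it is not alone there: the three values all sit at the limit of > 50000 nM in this assay, at which 3 of the 3 values shown sit. Going by the values given here, the one step that can be paired, a methyl in place of hydrogen on an aromatic carbon, is a step that the two limits leave unreadable from compound 1 to compound 3, so it gives no size to work with. Among the compounds with values here, compound 2 also stops at its limit, and no step between it and compound 1 is available.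

Compound 4 `C/C(=C\c1cc(-c2ccc(S(C)(=O)=O)cc2)cs1)C(N)=O` differs from compound 1 by methylsulfonyl in place of hydrogen on an aromatic carbon. The measured steps bear on this change only in that none of them produced a number that left the limit; no direction and no size can be read from them. The expectation is therefore that the step from compound 1 to compound 4 shows nothing beyond the scatter in this assay, expected as a step that the limit leaves unreadable from compound 1 to compound 4. On that basis compound 4 is estimated at 60000 nM, with a range from 25000 nM to 150000 nM, most likely again reported only as a limit.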

Compound 4, half-maximal inhibitory concentration: > 50000 nM
Compound 4 was reported as a limit; the forecaster's own chance of this, stated with the estimate: 85%; the middle value is on the limit's open side.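

Compound 4 stops at a limit in this assay, just as compound 1 does, so no size or direction can be read for the step between them: the limit of > 50000 nM in this assay, at which 4 of the 4 values shown sit.

The compounds shown leave open how far beyond that limit each one lies, and which change, if any, would bring a compound to a readable number in this assay.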